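The source may report more compounds than this note shows. Statements on the series, on what has been measured and on what is new or still open speak of the compounds shown alone.

In an ADME assay on Huh-7 cells (Homo sapiens) for cytotoxicity, with a stated time of 72 h (a higher number here means that more compound is tolerated, a lower number that less compound is tolerated), compound 1 (`Cc1cn([C@@H]2O[C@H](CO[Si](C)(C)C(C)(C)C)[C@@]3(OS(=O)(=O)C=C3N)[C@H]2O[Si](C)(C)C(C)(C)C)c(=O)n(C(=O)c2ccccc2)c1=O`) gives > 100000 nM as a limit of the assay. Compound 2 (`Cc1cn([C@@H]2O[C@H](CO[Si](C)(C)C(C)(C)C)[C@@]3(OS(=O)(=O)C=C3N)[C@H]2O[Si](C)(C)C(C)(C)C)c(=O)n(C(=O)CCCC(N)=O)c1=O`) gives > 100000 nM as a limit too, so its standing is known only as a limit and not as a number. Both readings in the series sit at the limit of > 100000 nM in this assay, at which 2 of the 2 values shown sit, and neither compound has a number of its own. Compound 3 (`Cc1cn([C@@H]2O[C@H](CO[Si](C)(C)C(C)(C)C)[C@@]3(OS(=O)(=O)C=C3N)[C@H]2O[Si](C)(C)C(C)(C)C)c(=O)n(C(=O)CCCC(=O)N(C)C)c1=O`) differs from compound 2 by dimethylamino in place of amino on a carbonyl carbon with dimethylamino in place of amino on a carbonyl carbon. Among the measured compounds shown here, the one measured step is a step that the two limits leave unreadable from compound 1 to compound 2 for 3-carbamoylpropyl in place of phenyl on a carbonyl carbon and offers no size to carry over, so no step beyond the scatter is expected in this assay. The estimated step is a number no higher from compound 2 to compound 3 (the limit leaves the size open) with no direction favoured. Compound 3 is estimated at 100000 nM within a range of 40000 nM to 200000 nM and is expected to be reported most likely as a limit.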

Compound 3, half-maximal cytotoxic concentration: > 100000 nM
Compound 3: no number, only a limit; the forecaster's own chance of this, stated with the estimate: 80%; the middle value sits exactly at the limit.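

No new step can be read between compound 1, compound 2 and compound 3 in this assay, since all three results are limits and not numbers: the limit of > 100000 nM in this assay, at which 3 of the 3 values shown sit.

The compounds shown leave open at what concentration any of them becomes cytotoxic, and whether exchanging the groups on the carbonyl carbon changes that concentration.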